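Swapping a Piperazine Carbamate for Diethylamino on a Shared Core

The source may hold more compounds than are shown below. What is called first, only, known or untested is meant among the compounds shown, and "the series" means these compounds.

Compound 1 `CCOC(=O)N1CCN(/[N+]([O-])=N/Oc2cc(O/N=[N+](\[O-])N(C)C)c([N+](=O)[O-])cc2[N+](=O)[O-])CC1` and compound 2 `CCN(CC)/[N+]([O-])=N/Oc1cc(O/N=[N+](\[O-])N(C)C)c([N+](=O)[O-])cc1[N+](=O)[O-]` share one core and differ in a single place: diethylamino in place of 4-(ethoxycarbonyl)piperazin-1-yl on a double-bonded nitrogen. Both were tested in a functional assay on HL-60 cells (Homo sapiens) for antiproliferative activity, read by MTT assay, with a stated time of 72 h; on this read-out higher numbers stand for weaker inhibition and lower numbers for stronger inhibition. Compound 1 gives 1200 nM, and compound 2 gives 1000 nM. The step between them amounts to a 1.2-fold lower number from compound 1 to compound 2 (0.08 log units; within the scatter), small enough to count as no real change in this series.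

Compound 3 `CCOC(=O)N1CCN(/[N+]([O-])=N/Oc2cc(O/N=[N+](\[O-])N3CCN(C(=O)N(CC)CC)CC3)c([N+](=O)[O-])cc2[N+](=O)[O-])CC1` is built on a different core; how its core differs from that of compound 1 is not broken down here. In this assay compound 3 gives 900 nM, a number that sits close to those of compound 1 and compound 2, so all three fall within the usual repeat scatter of one another.

Compound 4 `CCN(CC)C(=O)N1CCN(/[N+]([O-])=N/Oc2cc(O/N=[N+](\[O-])N(CC)CC)c([N+](=O)[O-])cc2[N+](=O)[O-])CC1` has not been measured yet. It differs from compound 3 by the same single change seen between compound 1 and compound 2: diethylamino in place of 4-(ethoxycarbonyl)piperazin-1-yl on a double-bonded nitrogen. The surroundings of the place where the change is made read the same in both pairs, so it is the same change carried onto the second core.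

Because the first instance gave a 1.2-fold lower number from compound 1 to compound 2 (0.08 log units; within the scatter), a step of similar small size is expected, estimated as a 1.2-fold lower number from compound 3 to compound 4 (0.08 log units; within the scatter). That rests on one precedent only, so the expected number for compound 4 in this assay is 750 nM, with a plausible range from 400 nM to 1500 nM.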

Compound 4, half-maximal inhibitory concentration: 2900 nM
Compound 4: the middle estimate sits 3.9-fold (0.59 log units) below what was measured; measured number outside the range, above it.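

In this assay, putting diethylamino in place of 4-(ethoxycarbonyl)piperazin-1-yl on the second core gives a 3.2-fold higher number from compound 3 to compound 4 (0.51 log units; beyond the scatter), a modest step towards weaker inhibition. Set beside the first instance, the swap did not carry over unchanged from one core to the other: the same change on two cores in this assay, a 1.2-fold lower number (0.08 log units; within the scatter) from compound 1 to compound 2 and a 3.2-fold higher number (0.51 log units; beyond the scatter) from compound 3 to compound 4, 3.9-fold (0.59 log units) apart, beyond the scatter of two such steps So in these two pairs, the result of the swap depends on the core that carries it, and a step read on one core was a poor guide to the other; what this does not show is which part of the core matters, why it matters, or how the swap would behave on a third core.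

The compounds shown leave open whether a longer chain such as dipropylamino, put on the same double-bonded nitrogen, would also give different steps on the two cores. They also leave open whether a small amine such as methylamino would follow diethylamino on each core, which would help tell whether the difference between the cores is specific to diethylamino or holds for other groups in that place.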